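Substitution on the ring amine of a weakly active amide core

The compounds below may be only part of what the source reports. "The series", "measured", "known", "first", "only" and "open" are said of these compounds alone.

The shared core is carried by compound 1 `NC(=O)c1c(NC(=O)c2ccccc2Cl)sc2c1CCNC2`, which in a functional assay on HeLa cells (Homo sapiens) for antiproliferative activity, with a stated time of 24 h (a lower number here means a stronger inhibitor, a higher number a weaker inhibitor), gives 45000 nM. Compound 2 `Cc1ccc(C(=O)Nc2sc3c(c2C(N)=O)CCN(Cc2c(Cl)cccc2Cl)C3)cc1` gives 47400 nM in this assay, and compound 3 `NC(=O)c1c(NC(=O)c2ccccc2F)sc2c1CCN(Cc1ccc(Cl)cc1Cl)C2` gives 27500 nM in this assay. Compound 1 stands second highest of the three numbers; its value lies within the scatter of both compound 2 and compound 3, so no order among the three can be claimed, and all sit in a region of weak inhibition.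

Compound 4 `Cc1ccccc1NC(=S)N1CCc2c(sc(NC(=O)c3ccccc3Cl)c2C(N)=O)C1` has not been measured in this assay. Relative to compound 1 it carries a group of 10 heavy atoms (8 carbon, 1 nitrogen, 1 sulfur; one six-membered aromatic ring of carbon only) in place of a hydrogen atom, on an amine nitrogen in a ring. Among the compounds with values here, no pair of measured compounds differs in a single place, so no measured step is available for this change. What the numbers do show is that compound 2 and compound 3, both of which carry a substituent on the same amine nitrogen where compound 1 carries hydrogen, give values within the scatter of compound 1.

Expected for compound 4 is therefore a step no larger than the scatter, with the estimate a 1.3-fold lower number from compound 1 to compound 4 (0.11 log units; within the scatter) leaning slightly toward a lower number on the evidence of compound 3 at 27500 nM. The estimated value for compound 4 in this assay is 35000 nM, with a range from 12000 nM to 90000 nM.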

Compound 4, half-maximal inhibitory concentration: > 50000 nM
Compound 4: no number, only a limit; the forecaster's own chance of this, stated with the estimate: 15%; middle value at least 1.4-fold (0.15 log units) away from the limit.
By their numbers in this assay, from the lowest: compounds 3, 1 and 2 (each within the scatter of the next). At a limit, above all of these: compound 4.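

In this assay compound 4 gives > 50000 nM, which is a limit of the assay and not a number. Within the data shown here, this gives the series its first single-place step on the amine nitrogen in a ring, an at least 1.1-fold higher number from compound 1 to compound 4 (0.04 log units; that floor lies within the scatter), and it shows that putting the group of 10 heavy atoms in place of hydrogen at this position brings no lower number, whereas the earlier compounds changed this nitrogen only together with a second place. How far the step runs cannot be read from this result: the limit of > 50000 nM in this assay, at which 1 of the 4 values shown sits.

Compound 2 and compound 3 differ from compound 1 in more than one place, so what their substituents on this nitrogen contribute on their own stays unresolved. Also open, on these data alone, is whether a small group such as methyl or acetyl on this nitrogen, or a chain ending in an amine or a carboxylic acid, would move the number beyond the scatter of compound 1 in either direction.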